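A few compounds are considered here, and "the series" means these few. Any claim that something is new, unique, unknown or untested is made for them only; others in the source may bear on it.

Measured in a physicochemical assay for solubility, read by spectrophotometry, in phosphate buffer, with a stated time of 18 h, at pH 7.4; on this read-out higher numbers stand for higher solubility and lower numbers for lower solubility:
- compound 1 `CCc1ccc(-c2nc3c(c(C)nn3-c3ccccc3)c(-c3ccccc3Cl)c2C#N)cc1`: 1700 nM
- compound 2 `CCc1ccc(-c2nc3c(c(C)nn3-c3ccccc3)c(-c3ccccc3C(F)(F)F)c2C#N)cc1`: 11000 nM

Among the compounds with values here, of these two numbers, compound 2 stands higher at 11000 nM, and its only neighbour is compound 1 at 1700 nM. Compound 3 `CCc1ccc(-c2nc3c(c(C)nn3-c3ccccc3)c(-c3ccccc3C(=O)OC)c2C#N)cc1`, not yet measured, differs from compound 2 in one place: methoxycarbonyl in place of trifluoromethyl on an aromatic carbon, ortho to a large group (methoxycarbonyl in place of trifluoromethyl on an aromatic carbon).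

Within the data shown here, one measured step bears on this, made at the same place: a 6.5-fold higher number from compound 1 to compound 2 (0.81 log units; beyond the scatter), with trifluoromethyl in place of chloro. That step is modest but beyond the scatter, so a change here has moved the number in this assay. Among the measured compounds shown here, no measured compound carries methoxycarbonyl, however, so the data do not fix a direction. For the measured compounds named here, a step no larger than that one is expected, leaning slightly downward, given that compound 2 holds the higher of only two numbers at 11000 nM. The estimated step is a 1.8-fold lower number from compound 2 to compound 3 (0.26 log units; within the scatter). For compound 3 the expected value is 6000 nM, with an estimated range from 1500 nM to 25000 nM.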

Compound 3, solubility: 17000 nM
The estimate for compound 3 lay 2.8-fold (0.45 log units) below the measured number; the range from low to high includes it.
By their numbers in this assay, from the lowest: compound 1; then compounds 2 and 3 (each within the scatter of the next).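

In this assay methoxycarbonyl, with 2 hydrogen-bond acceptors, takes the place of trifluoromethyl, which has none, on this aromatic carbon ortho to a large group, and the result is a 1.5-fold higher number from compound 2 to compound 3 (0.19 log units; within the scatter); the two groups cannot be told apart by this read-out. Set against chloro at the same place, methoxycarbonyl gives a 10-fold higher number from compound 1 to compound 3 (1.00 log units; beyond the scatter), so compound 1 now stands apart from two compounds rather than one, the other step being a 6.5-fold higher number from compound 1 to compound 2 (0.81 log units; beyond the scatter), and among the three groups shown, chloro alone gives the lower number. Nothing shown here explains either the separation from chloro or the absence of one between trifluoromethyl and methoxycarbonyl.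

The compounds shown leave open where a carboxylic acid, an amine or a primary amide at this place would stand relative to compound 2 and compound 3 in this assay. Since all three compounds share one core, they also leave open whether the same exchanges would give similar steps with a different group elsewhere on it.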